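Extending the Amino Chain of Compound 3 with Hydroxymethyl

This account rests on a few compounds, and the source may have more. Where it says the series, first, only, none or still open, it means among the compounds named here.

Compound 1, `COc1cccnc1-c1cc(Cl)ccc1NS(=O)(=O)c1ccc(C(C)(C)C)cc1`: 958 nM
Compound 2, `CN(C)c1ncnc(-c2cc(Cl)ccc2NS(=O)(=O)c2ccc(C(C)(C)C)cc2)c1O`: 9 nM
Compound 3, `CCNc1nccnc1-c1cc(Cl)ccc1NS(=O)(=O)c1ccc(C(C)(C)C)cc1`: 421 nM

In a functional assay on isolated protein for antagonist activity at C-C chemokine receptor type 9 (Homo sapiens), read by calcium flux, with a stated time of 10 min (a higher number here means a weaker inhibitor, a lower number a stronger inhibitor), compound 3 gives 421 nM, the second-highest of the three numbers. Compound 1 gives 958 nM, and the step of a 2.3-fold lower number from compound 1 to compound 3 (0.36 log units; beyond the scatter) is a modest gain. Compound 2 gives 9 nM, and the step of a 47-fold higher number from compound 2 to compound 3 (1.67 log units; beyond the scatter) is a large loss. The widest shift among these three is a 110-fold lower number from compound 1 to compound 2 (2.03 log units; beyond the scatter).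

Compound 4, `CC(C)(C)c1ccc(S(=O)(=O)Nc2ccc(Cl)cc2-c2nccnc2NCCCO)cc1`, keeps the shared core of compound 3 and differs from it in one place: hydroxymethyl in place of hydrogen on a saturated chain carbon, two bonds along the chain from a nitrogen on an aromatic ring. In other words, the ethylamino arm becomes a (3-hydroxypropyl)amino arm.

Among the compounds with values here, none of the measured steps touches this arm. All three of them exchange the whole aromatic ring that carries it, so they tell how much the ring matters and say nothing about lengthening the chain that hangs from it. Without a step that bears directly on this change, the expected movement in this assay is small, and no shift beyond the scatter is anticipated in either direction; the range is set wide to reflect this. Compound 4 is therefore estimated at 350 nM, with a likely span from 100 nM to 1200 nM. The expected step is a 1.2-fold lower number from compound 3 to compound 4 (0.08 log units; within the scatter).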

Compound 4, half-maximal inhibitory concentration: 614 nM
Compound 4: middle estimate off by 1.8-fold (0.24 log units), on the low side, and the stated range covers the measured number.
By their numbers in this assay, from the lowest: compound 2; then compounds 3, 4 and 1 (each within the scatter of the next, the first and the last beyond it).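

In this assay, the step from the ethylamino arm to the (3-hydroxypropyl)amino arm is a 1.5-fold higher number from compound 3 to compound 4 (0.16 log units; within the scatter), so adding hydroxymethyl on this saturated chain carbon leaves the number indistinguishable from that of the parent. This is the first step shown that alters only the arm and leaves its aromatic ring in place; the earlier steps all exchanged the whole ring, and some of them moved the number far beyond the scatter, whereas this change to the arm does not. No measurement shown gives a reason why this change to the arm leaves the number where it is.

The compounds shown do not separate the extra chain length from the hydroxyl at its end, and a plain propyl arm, with the same chain as compound 4 but no hydroxyl, would tell the two apart. As far as these compounds go, it also remains open whether an arm ending in an amine or a carboxylic acid, or a longer chain than 3-hydroxypropyl, would shift the number beyond the scatter in either direction.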